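Shortening the thioether chain by one carbon

This account rests on a few compounds, and the source may have more. Where it says the series, first, only, none or still open, it means among the compounds named here.

For the measured compounds named here, compound 2 `CCCCSc1nsnc1[C@H]1CN2CCC[C@@H]1C2` is the only compound with a number in a functional assay on the whole organism for inhibition, with Rattus norvegicus as the target (a higher number here means that more compound is needed for the effect, a lower number that less compound is needed), where compound 2 gives 0.017 mg/kg. Its partner compound 1 `CCCCSc1nsnc1[C@@H]1CN2CCC[C@@H]1C2` reaches only a limit of the assay: in this assay compound 1 gives > 3 mg/kg. Going by the values given here, the step of an at least 170-fold lower number from compound 1 to compound 2 (2.24 log units; beyond the scatter) is the sole measured step, and it concerns a change of drawn configuration at a ring carbon, as noted in the fact that one of compounds 1 and 2 is drawn with a defined configuration and the other without, at the place where they differ; it tells nothing about the chain on the sulfur. Compound 3 `CCCSc1nsnc1[C@H]1CN2CCC[C@@H]1C2` differs from compound 2 by hydrogen in place of methyl on a saturated chain carbon, three bonds along the chain from a sulfur. Among the compounds with values here, no measured step bears on this change, so the expectation rests on compound 2 at 0.017 mg/kg alone. A modest step of a 1.8-fold higher number from compound 2 to compound 3 (0.25 log units; within the scatter) toward a higher number is expected, not clearly beyond the scatter. For compound 3 an estimate of 0.03 mg/kg is given, with a range from 0.008 mg/kg to 0.12 mg/kg.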

Compound 3, dose for half-maximal effect: 0.013 mg/kg
The estimate for compound 3 lay 2.3-fold (0.36 log units) above the measured number; measured number inside the range.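

In this assay the move from butyl to propyl on the sulfur is a 1.3-fold lower number from compound 2 to compound 3 (0.12 log units; within the scatter) and so the two compounds cannot be told apart. For the compounds shown here, the earlier step spoke only to a drawn configuration at a ring carbon, so this is the first reading on the chain itself, and it shows that this place accepts hydrogen in place of methyl with no change beyond the scatter. Nothing given here explains why the removal of this methyl leaves the number within the scatter.

A single step cannot describe a trend along the chain, and it comes from this one assay alone. On these data alone, how a longer chain such as hexyl, or a chain carrying an amine or a carboxylic acid, would read at this place remains open.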